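The source may hold more compounds than are shown below. What is called first, only, known or untested is meant among the compounds shown, and "the series" means these compounds.

Three compounds of the series have been run in an ADME assay on L02 cells (Homo sapiens) for cytotoxicity, read by MTT assay, with a stated time of 48 h (on this read-out higher numbers stand for weaker inhibition and lower numbers for stronger inhibition), and every one of them returned only a limit. Compound 1 `Cc1ccc2[nH]c(=O)c(-c3nc4cc([N+](=O)[O-])ccc4[nH]3)cc2c1` carries a nitro group on an aromatic carbon of its core; in this assay compound 1 sits at > 100000 nM, which is a limit of the assay and not a number. Compound 2 `O=c1[nH]c2ccccc2cc1-c1nc2cc(F)ccc2[nH]1` carries a fluoro group; in this assay compound 2 likewise reports only the limit > 100000 nM. Compound 3 `Cc1ccc2[nH]c(=O)c(-c3nc4ccccc4[nH]3)cc2c1` carries neither group; in this assay compound 3 also reaches only the limit > 100000 nM. On the numbers shown, compound 3 therefore stands nowhere in particular: only a limit is known for it, and the two further values are limits too, as the limit of > 100000 nM in this assay, at which 3 of the 3 values shown sit, records. Going by the values given here, the single step between measured compounds, a step that the two limits leave unreadable from compound 1 to compound 3, cannot be read for the same reason.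

Compound 4 `Cc1ccc2[nH]c(=O)c(-c3nc4cc(F)ccc4[nH]3)cc2c1` differs from compound 3 by fluoro in place of hydrogen on an aromatic carbon. Among the compounds with values here, no measured step bears on this change with a readable size, and compound 2, which also carries fluoro, ends at the limit like the rest. The expectation in this assay is accordingly a step of no readable size, a step that the limit leaves unreadable from compound 3 to compound 4, with the result most likely another limit. Compound 4 is estimated at 150000 nM, within 50000 nM to 500000 nM.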

Compound 4, half-maximal inhibitory concentration: > 100000 nM
Compound 4: a limit, no number; the forecaster's own chance of this, stated with the estimate: 90%; the middle value lies beyond the limit too.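

In this assay compound 4 gives > 100000 nM, a limit and not a number. Going by these compounds alone, the steps to compound 4 from compound 1, compound 2 and compound 3 therefore cannot be read, and no new step emerges: the limit of > 100000 nM in this assay, at which 4 of the 4 values shown sit. The compounds shown leave open how large any of these changes on an aromatic carbon is in this assay.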